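A Sulfamoyl Exchange on Compound 1

The compounds below may be only part of what the source reports. "The series", "measured", "known", "first", "only" and "open" are said of these compounds alone.

For the measured compounds named here, only two compounds have been measured so far: compound 1 (`Cc1cc(C)cc(S(=O)(=O)n2c(SCC(=O)Nc3ccc(C(=O)O)cc3)nc3ccccc32)c1`) and compound 2 (`Cc1cc(C)cc(S(=O)(=O)n2c(OCC(=O)Nc3ccccc3Cl)nc3ccccc32)c1`). In an ADME assay on MT4 cells (Homo sapiens) for cytotoxicity, read by MTT assay, with a stated time of 5 days (on this read-out lower numbers stand for higher toxicity in this test and higher numbers for lower toxicity in this test), compound 1 gives 115000 nM and compound 2 gives 169000 nM. Going by the values given here, these two values lie within the usual scatter of each other, so compound 1 cannot be separated from the only other number available.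

The next compound to be tested is compound 3 (`Cc1cc(C)cc(S(=O)(=O)n2c(SCC(=O)Nc3ccc(S(N)(=O)=O)cc3Cl)nc3ccccc32)c1`). It carries 2-chloro-4-sulfamoylphenyl in place of 4-carboxyphenyl on an amide-type nitrogen, and the counted difference is 2-chloro-4-sulfamoylphenyl in place of 4-carboxyphenyl on an amide-type nitrogen. The rest of compound 1 is unchanged.

Among the compounds with values here, no measured pair isolates this exchange, so the data do not show directly what it does in this assay. The expectation therefore starts from compound 1 at 115000 nM and assumes no clear move in either direction. The expected change, a 1.2-fold lower number from compound 1 to compound 3 (0.06 log units; within the scatter), is estimated to stay within the usual scatter. Within the data shown here, the uncertainty remains wide, since only two measurements anchor it. For compound 3 the estimated value is 100000 nM, with an expected range from 35000 nM to 250000 nM.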

Compound 3, half-maximal cytotoxic concentration: 25600 nM
The estimate for compound 3 lay 3.9-fold (0.59 log units) above the measured number, outside the stated range (below it).
By their numbers in this assay, from the lowest: compound 3; then compounds 1 and 2 (each within the scatter of the next).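

In this assay, placing 2-chloro-4-sulfamoylphenyl in place of 4-carboxyphenyl on an amide-type nitrogen gives a 4.5-fold lower number from compound 1 to compound 3 (0.65 log units; beyond the scatter). For the compounds shown here, this is the first step that lies beyond the usual scatter, and it shows that the group on this nitrogen can shift the read-out, if only modestly, towards higher toxicity in this test, something the earlier pair of compounds, which differ in more than one place, could not show. No supporting measurement bears on why the number falls, so the result stands here as an observation without an explanation.

The compounds shown leave open which part of the exchange carries the step, as the sulfamoyl group and the chlorine enter together while the carboxylic acid leaves, and the single step cannot divide the shift among these changes. From the compounds shown here alone, a 4-sulfamoylphenyl group without the chlorine, or a 2-chloro-4-carboxyphenyl group, on the same nitrogen would separate these parts, and it also remains open whether the step would hold on a different core.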